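Swapping a thiophene for a phenol on a chalcone chain

The source may hold more compounds than are shown below. What is called first, only, known or untested is meant among the compounds shown, and "the series" means these compounds.

Two compounds of a shared core have been examined in a functional assay on HT-29 cells (Homo sapiens) for antiproliferative activity, read by MTT assay, with a stated time of 24 h; a lower number here means a stronger inhibitor, a higher number a weaker inhibitor. Compound 1 `COc1ccc(C(=O)/C=C/c2ccc(-n3ccnc3)cc2)c2c1C=CC(C)(C)O2` reaches only the limit of the assay, returning > 6600 nM. Compound 2 `COc1ccc(C(=O)/C=C/c2ccsc2)c2c1C=CC(C)(C)O2` likewise gives only a limit, > 10000 nM. Both numbers are therefore limits rather than measured values, as the lines the limit of > 10000 nM in this assay, at which 1 of the 2 values shown sits, and the limit of > 6600 nM in this assay, at which 1 of the 2 values shown sits, record, so compound 2 cannot be placed above or below compound 1; it stands among values that were not resolved by this assay. Compound 3 `COc1ccc(C(=O)/C=C/c2cccc(O)c2)c2c1C=CC(C)(C)O2` is the next member, differing from compound 2 by one change: 3-hydroxyphenyl in place of thiophen-3-yl on a double-bonded chain carbon bound to a double-bonded chain carbon. For the measured compounds named here, with no measured step of this kind to lean on, the size of the change from compound 2 to compound 3 in this assay is expected to be modest and perhaps toward stronger inhibition, an at least 1.2-fold lower number from compound 2 to compound 3 (0.09 log units; that floor lies within the scatter), though it may well stay within the scatter. Compound 3 is thus estimated at 8000 nM, with a range from 2000 nM to 30000 nM.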

Compound 3, half-maximal inhibitory concentration: > 10000 nM
Compound 3 was reported as a limit (the forecaster's own chance of this, stated with the estimate: 60%); at least 1.2-fold (0.09 log units) between middle value and limit.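

Compound 2 and compound 3 both return only a limit in this assay, so the step between them cannot be read: the limit of > 10000 nM in this assay, at which 2 of the 3 values shown sit. The compounds shown leave open whether 3-hydroxyphenyl or thiophen-3-yl gives the stronger inhibition in this assay.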